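Methyl Gives Way to a Carboxypyridinylmethyl Arm on the Amine

A few compounds are considered here, and "the series" means these few. Any claim that something is new, unique, unknown or untested is made for them only; others in the source may bear on it.

Compound 3 `CN1CCC[C@H](OCc2cc(Cl)cc(Cl)c2)[C@@H]1c1ccccc1` carries a methyl on the ring amine of the shared core. In an assay on isolated protein for activation of cGMP-dependent protein kinase 1 (Homo sapiens), read by ADP-Glo, with stated times of 120 min and 40 min (on this read-out higher numbers stand for an effect only at larger amounts of compound and lower numbers for an effect already at smaller amounts), compound 3 gives > 200000 nM, which is a limit of the assay and not a number. Compound 1 `Clc1cc(Cl)cc(CO[C@H]2CCCN(Cc3ccccn3)[C@H]2c2ccccc2)c1` bears pyridin-2-yl on a saturated chain carbon bound to an amine nitrogen in a ring; in this assay compound 1 gives > 200000 nM, again a limit rather than a number. Compound 2 `Clc1cc(Cl)cc(CO[C@H]2CCCN(Cc3ncco3)[C@H]2c2ccccc2)c1` bears 1,3-oxazol-2-yl at the same place, and in this assay compound 2 gives > 200000 nM, also a limit. The steps a step that the two limits leave unreadable from compound 1 to compound 2, a step that the two limits leave unreadable from compound 1 to compound 3 and a step that the two limits leave unreadable from compound 2 to compound 3 therefore cannot be sized, because of the limit of > 200000 nM in this assay, at which 3 of the 3 values shown sit.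

Compound 4 `O=C(O)c1cncc(CN2CCC[C@H](OCc3cc(Cl)cc(Cl)c3)[C@@H]2c2ccccc2)c1` differs from compound 3 by 5-carboxypyridin-3-yl in place of hydrogen on a saturated chain carbon bound to an amine nitrogen in a ring. Every measured step rests on two limits, so none of them shows a readable size or direction, and they give no ground to expect a change beyond the scatter in any particular direction. The estimate for compound 4 in this assay is 200000 nM, with a range from 40000 nM to 1000000 nM, and it is expected most likely to return as a limit once more. This estimate means an expected step of a number no higher from compound 3 to compound 4 (the limit leaves the size open).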

Compound 4, half-maximal effective concentration: 117000 nM
Compound 4: middle estimate off by 1.7-fold (0.23 log units), on the high side; the range from low to high includes it.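

Compound 4 is the first compound shown to give a number rather than a limit in this assay, so a change at this place, on a saturated chain carbon bound to an amine nitrogen in a ring, can now be given a direction, though only as a floor. Set against hydrogen, 5-carboxypyridin-3-yl gives an at least 1.7-fold lower number from compound 3 to compound 4 (0.23 log units; that floor lies within the scatter); set against 1,3-oxazol-2-yl, it gives an at least 1.7-fold lower number from compound 2 to compound 4 (0.23 log units; that floor lies within the scatter); and set against pyridin-2-yl, it gives an at least 1.7-fold lower number from compound 1 to compound 4 (0.23 log units; that floor lies within the scatter). All three floors remain within the scatter, and the steps among the other compounds still cannot be read, because those compounds all sit at one limit: the limit of > 200000 nM in this assay, at which 3 of the 4 values shown sit.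

The compounds shown do not separate the part played by the carboxylic acid from that of the pyridine ring carrying it, so what a methyl ester or a primary amide would give in its place remains open. Also open, from the compounds shown here alone, is how far the true step extends, and whether a longer chain between the ring amine nitrogen and the pyridine ring would shift the number.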